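From 4-nitrobenzyl to 2,6-difluorobenzyl: an expected small step

The source may hold more compounds than are shown below. What is called first, only, known or untested is meant among the compounds shown, and "the series" means these compounds.

In a functional assay on SW 1116 cells (Homo sapiens) for antiproliferative activity, read by MTT assay, with a stated time of 24 h (on this read-out higher numbers stand for weaker inhibition and lower numbers for stronger inhibition), compound 1 (`O=[N+]([O-])c1ccc(CSc2nnc(-c3ccc4c(c3)OCCO4)n2-c2ccccc2)cc1`) gives 13800 nM, and compound 2 (`COc1cccc(CSc2nnc(-c3ccc4c(c3)OCCO4)n2-c2ccccc2)c1`) gives 10100 nM. For the measured compounds named here, these are the only two numbers available, and they lie within the scatter of each other, so compound 1 stands level with its one neighbour. Compound 3 (`Fc1cccc(F)c1CSc1nnc(-c2ccc3c(c2)OCCO3)n1-c1ccccc1`) has not yet been measured. Its difference from compound 1 is 2,6-difluorophenyl in place of 4-nitrophenyl on a saturated chain carbon bound to a sulfur, which places 2,6-difluorophenyl on the saturated chain carbon bound to a sulfur. Going by the values given here, one measured step bears on this, as the group at that same place also changes in a 1.4-fold lower number from compound 1 to compound 2 (0.14 log units; within the scatter). Among the compounds with values here, no measured compound carries 2,6-difluorophenyl, so this single step is weak guidance, and no shift beyond the scatter is expected. The expected change is a 1.2-fold lower number from compound 1 to compound 3 (0.08 log units; within the scatter). For compound 3 the estimated value is 11500 nM, with an expected range from 5000 nM to 26000 nM.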

Compound 3, half-maximal inhibitory concentration: 9010 nM
Beside the measured number, compound 3's estimate is 1.3-fold (0.11 log units) above it; measured number inside the range.
By their numbers in this assay, from the lowest: compounds 3, 2 and 1 (each within the scatter of the next).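

In this assay, a third group on the saturated chain carbon bound to a sulfur again leaves the number within the scatter, with a 1.5-fold lower number from compound 1 to compound 3 (0.19 log units; within the scatter) and with a 1.1-fold lower number from compound 2 to compound 3 (0.05 log units; within the scatter). Where the earlier pair offered a single exchange at this place, 4-nitrophenyl, 3-methoxyphenyl and 2,6-difluorophenyl now all read alike, even though 2,6-difluorophenyl carries no hydrogen-bond acceptors and 4-nitrophenyl carries some. No measurement is at hand that would explain this sameness.

From the compounds shown here alone, whether any group at this place can move the number beyond the scatter stays open, for instance a ring bearing an amine or a carboxylic acid, or a longer chain in place of the benzyl unit. The compounds shown also say nothing about changes elsewhere on the shared core, since all of them keep it unchanged.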